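The source may report more compounds than this note shows. Statements on the series, on what has been measured and on what is new or still open speak of the compounds shown alone.

Working notes on the series: two compounds have numbers so far in a functional assay on PC-3 cells (Homo sapiens) for antiproliferative activity, read by luminescence, with a stated time of 72 h; a higher number here means a weaker inhibitor, a lower number a stronger inhibitor. Compound 1 (`CN1CC=C(c2c(O)cc(O)c3c(=O)cc(-c4ccc(Sc5nc6ccccc6[nH]5)cc4)oc23)CC1`) gives 742 nM, and compound 2 (`CN1CC=C(c2c(O)cc(O)c3c(=O)cc(-c4ccc(Sc5nc6ccccc6n5C)cc4Cl)oc23)CC1`) gives 85 nM, the lower of the two numbers and beyond the scatter from compound 1. Next in line is compound 3 (`CN1CC=C(c2c(O)cc(O)c3c(=O)cc(-c4ccc(Sc5nc6ccccc6[nH]5)cc4Cl)oc23)CC1`), which departs from compound 2 in one place: hydrogen in place of methyl on an aromatic nitrogen, (hydrogen in place of methyl on an aromatic nitrogen). This turns the (1-methyl-1H-benzimidazol-2-yl)sulfanyl group into the (1H-benzimidazol-2-yl)sulfanyl group, which is also carried by compound 1 at 742 nM. Going by the values given here, no measured pair isolates this change, so the size of the step remains uncertain. A moderate step to a higher number is expected in this assay, the estimated change being a 2.6-fold higher number from compound 2 to compound 3 (0.41 log units; beyond the scatter). Compound 3 is estimated at 220 nM, with an expected range of 80 nM to 600 nM.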

Compound 3, half-maximal inhibitory concentration: 326 nM
Estimate against measurement, compound 3: 1.5-fold (0.17 log units) below; the measured number falls inside the stated range.
By their numbers in this assay, from the lowest: compound 2; then compound 3; then compound 1.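

In this assay, the methyl on the aromatic nitrogen now has a measured step of its own with the chloro group held in place: hydrogen in place of methyl gives a 3.8-fold higher number from compound 2 to compound 3 (0.58 log units; beyond the scatter). Going by these compounds alone, the chloro group is also isolated for the first time, as chloro in place of hydrogen on an aromatic carbon gives a 2.3-fold lower number from compound 1 to compound 3 (0.36 log units; beyond the scatter) with the 1H-benzimidazol-2-yl group held in place, so both single changes on the path between the first two compounds are now read, and the methyl and the chloro each go with a lower number. No measurement in hand speaks to the origin of either step.

On these data alone, whether the methyl step keeps its size without the chloro group remains open, as does whether the chloro step keeps its size with the methyl present. Also open, as far as these compounds go, is how an ethyl group or a longer chain on that nitrogen, or fluoro or methoxy in place of the chloro, would read in this assay.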